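Chain lengthening in an isothiocyanate-bearing series

This account rests on a few compounds, and the source may have more. Where it says the series, first, only, none or still open, it means among the compounds named here.

Measured compounds:
Compound 1, `CN(C)C(=O)c1cc2cnc(Nc3ccc(S(=O)(=O)NCCCCCN=C=S)cc3)nc2n1C1CCCC1`: 52.1%
Compound 2, `CN(C)C(=O)c1cc2cnc(Nc3ccc(NC(=O)CCCN=C=S)cc3)nc2n1C1CCCC1`: 39.7%

In a functional assay on NCI-H1299 cells (Homo sapiens) for inhibition, read by CCK-8 assay, with a stated time of 72 h, tested at 1 uM (on this read-out lower numbers stand for a weaker effect and higher numbers for a stronger effect at the one concentration tested), compound 2 stands lowest of the two, with compound 1 nearest and the only step shown, a number 12.4 percentage points lower from compound 1 to compound 2 (beyond the scatter). Compound 3, `CN(C)C(=O)c1cc2cnc(Nc3ccc(NC(=O)CCCCCN=C=S)cc3)nc2n1C1CCCC1`, differs from compound 2 by a group of 5 heavy atoms (3 carbon, 1 nitrogen, 1 sulfur; no ring) in place of a group of 3 heavy atoms (1 carbon, 1 nitrogen, 1 sulfur; no ring), on a saturated chain carbon, three bonds along the chain from a carbonyl carbon. Within the data shown here, the one measured step changes both the linker and the chain at once, so it bears only loosely on this pure chain lengthening. Compound 3 is therefore expected to move little from compound 2 in this assay, the estimated step being a number 5.3 percentage points higher from compound 2 to compound 3 (within the scatter). The estimate for compound 3 is 45%, with a range from 30% to 60%.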

Compound 3, a percentage reported as inhibition, at one concentration (the size of the read-out at that concentration, not a potency): 34.3%
Estimate against measurement, compound 3: 10.7 percentage points above; the range from low to high includes it.
By their numbers in this assay, from the lowest: compounds 3 and 2 (each within the scatter of the next); then compound 1.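

In this assay, the longer group on the saturated chain carbon, three bonds along the chain from a carbonyl carbon, gives a number 5.4 percentage points lower from compound 2 to compound 3 (within the scatter), so this chain lengthening shows no separable effect at this position. The change on the aromatic carbon gives a number 17.8 percentage points lower from compound 1 to compound 3 (beyond the scatter), which places compound 1 beyond the scatter of the longer chain as well as the shorter one. No evidence available here accounts for either step. The compounds shown leave open whether a still longer chain would behave the same way. They also leave open what an amine or a carboxylic acid would give in place of the isothiocyanate.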